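A Second Trifluoromethyl Group on the Urea Aryl Ring

This account rests on a few compounds, and the source may have more. Where it says the series, first, only, none or still open, it means among the compounds named here.

Compound 1 `O=C(Nc1cccc(-n2cc(-c3ccncc3)c(-c3ccc(Cl)c(O)c3)n2)c1)Nc1cccc(C(F)(F)F)c1` and compound 2 `O=C(Nc1cccc(-n2cc(-c3ccncc3)c(-c3ccc(Cl)c(O)c3)n2)c1)Nc1ccc(Cl)c(Cl)c1` share one core and differ only in the aryl ring on the far nitrogen of the urea. In a functional assay on NCI-H322M cells (Homo sapiens) for inhibition, read by sulforhodamine B assay, with a stated time of 48 h (on this read-out lower numbers stand for stronger inhibition of growth and higher numbers for weaker inhibition of growth), compound 1 gives 6410 nM, and compound 2 gives 2890 nM. Of the two numbers measured, compound 1 stands highest, so its growth inhibition is the weaker; the swap to 3,4-dichlorophenyl brought a 2.2-fold lower number from compound 1 to compound 2 (0.35 log units; beyond the scatter).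

Compound 3 `O=C(Nc1cccc(-n2cc(-c3ccncc3)c(-c3ccc(Cl)c(O)c3)n2)c1)Nc1cc(C(F)(F)F)cc(C(F)(F)F)c1` keeps the whole of compound 1 and changes it in one place: trifluoromethyl in place of hydrogen on an aromatic carbon. Among the compounds with values here, no measured step puts a second trifluoromethyl onto this ring, so the only guide is the single change of aryl ring from compound 1 to compound 2, which moved the number modestly. A step of similar modest size, or none beyond the scatter, is therefore expected, most likely toward a lower number, giving a 1.4-fold lower number from compound 1 to compound 3 (0.15 log units; within the scatter). For compound 3 the estimate is 4500 nM, expected to fall between 2000 nM and 10000 nM.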

Compound 3, concentration for 50% growth inhibition: 1310 nM
For compound 3 the middle estimate is 3.4-fold (0.54 log units) above the measured one; the whole stated range lies above it.
By their numbers in this assay, from the lowest: compound 3; then compound 2; then compound 1.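

In this assay the added trifluoromethyl group brings a 4.9-fold lower number from compound 1 to compound 3 (0.69 log units; beyond the scatter) and so shows that this aromatic carbon, which carried only hydrogen in compound 1, can take a substituent with a gain in growth inhibition. The earlier step exchanged one whole aryl ring for another, whereas this one changes a single place on the ring, so the shift can be tied to that one addition. Nothing in the data explains why the number falls.

The compounds shown leave open whether trifluoromethyl itself matters at this place or whether another group, such as a chlorine atom, an amine or a carboxylic acid, would serve as well. They also leave open whether the same addition would bring a similar shift on a different aryl ring.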